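A Methyl Added to Compound 2 in This Assay

The compounds below may be only part of what the source reports. "The series", "measured", "known", "first", "only" and "open" are said of these compounds alone.

Compound 2 `Cc1cc(C)nc(SCc2cc(=O)c3ccccc3o2)n1` is one of three compounds examined in a functional assay on MCF7 cells (Homo sapiens) for cytotoxicity, read by MTT assay, with a stated time of 72 h; on this read-out lower numbers stand for stronger inhibition and higher numbers for weaker inhibition. In this assay compound 2 gives only a limit, > 25000 nM, and not a number. Compound 1 `Cc1cc(C)nc(SCc2cc(=O)c3cc(Cl)ccc3o2)n1` likewise reaches only a limit in this assay, > 25000 nM. Within the data shown here, the single measured one-point step, a step that the two limits leave unreadable from compound 1 to compound 2, therefore cannot be read, as the limit of > 25000 nM in this assay, at which 2 of the 3 values shown sit, shows. Compound 3 `O=c1c(CSc2nc3ccccc3o2)coc2ccccc12`, built on a different core, gives 4800 nM in this assay.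

Compound 4 `Cc1ccc2oc(CSc3nc(C)cc(C)n3)cc(=O)c2c1` differs from compound 2 by methyl in place of hydrogen on an aromatic carbon. Among the measured compounds shown here, no measured step concerns a methyl in place of hydrogen on this core, and the only step between measured compounds is unreadable, so the data yield no size of step to carry over. Compound 4 is therefore expected to remain near the limit of compound 2, with the estimated step that the limit leaves unreadable from compound 2 to compound 4 not expected to go beyond the scatter. Compound 4 is estimated at 30000 nM, between 8000 nM and 100000 nM, and is expected most likely to be reported again only as a limit.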

Compound 4, half-maximal inhibitory concentration: > 25000 nM
Compound 4: no number, only a limit; the forecaster's own chance of this, stated with the estimate: 75%; the middle value does not contradict the limit.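

No new step can be read among compound 1, compound 2 and compound 4 in this assay, because all three give only a limit and not a number: the limit of > 25000 nM in this assay, at which 3 of the 4 values shown sit.

The compounds shown leave open how hydrogen, chloro and methyl on this aromatic carbon of the shared core compare in this assay.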